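Swapping amino for fluoro on a cytotoxicity read-out

This account rests on a few compounds, and the source may have more. Where it says the series, first, only, none or still open, it means among the compounds named here.

Measured compounds:
compound 1 `CNc1ccc(Sc2ccc([N+](=O)[O-])cc2)c(C(=O)Nc2ccccc2OC)c1` gives 302000 nM
compound 2 `COc1ccccc1NC(=O)c1cc(N)ccc1Sc1ccc([N+](=O)[O-])cc1` gives 506000 nM
compound 3 `COc1ccccc1NC(=O)c1cscc1Sc1ccc([N+](=O)[O-])cc1` gives 518000 nM

In an ADME assay on H9 cells (Homo sapiens) for cytotoxicity, read by MTT assay, with a stated time of 7 days (on this read-out higher numbers stand for lower toxicity in this test and lower numbers for higher toxicity in this test), compound 2 stands second highest of the three numbers; its nearest neighbour is compound 3, and compound 1 lies furthest away, yet both of these gaps are within the scatter, so the three compounds cannot be told apart on this read-out.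

Compound 4 `COc1ccccc1NC(=O)c1cc(F)ccc1Sc1ccc([N+](=O)[O-])cc1` has not been measured. It is compound 2 with fluoro in place of amino on an aromatic carbon.

Going by the values given here, only one measured step changes a single place: a 1.7-fold higher number from compound 1 to compound 2 (0.22 log units; within the scatter), a change on the nitrogen of the very group that compound 4 loses. That step stayed within the scatter. Among the compounds with values here, no measured step exchanges amino for fluoro, so the move to compound 4 has no direct precedent, and the whole set so far spans a spread no wider than the scatter itself.

On that basis compound 4 is expected to show a 1.1-fold lower number from compound 2 to compound 4 (0.05 log units; within the scatter), a step not beyond the scatter in either direction. The estimate for compound 4 in this assay is 450000 nM, with a range from 200000 nM to 1000000 nM.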

Compound 4, half-maximal cytotoxic concentration: 502000 nM
Beside the measured number, compound 4's estimate is 1.1-fold (0.05 log units) below it; low and high end bracket the measured number.
By their numbers in this assay, from the lowest: compounds 1, 4, 2 and 3 (each within the scatter of the next).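

In this assay, exchanging amino directly for fluoro on this aromatic carbon gives a 1.0-fold lower number from compound 2 to compound 4 (0.00 log units; within the scatter), even though amino carries a hydrogen-bond donor and acceptor and fluoro carries neither. Going by these compounds alone, the comparison with the methylamino compound gives a 1.7-fold higher number from compound 1 to compound 4 (0.22 log units; within the scatter), so methylamino, amino and fluoro on this carbon all lie within the scatter of one another, and the earlier compounds, which offered only a change on the nitrogen, could not show that a group without nitrogen also fits this pattern. Nothing measured here explains why these groups cannot be told apart in this test.

The compounds shown leave open whether a carboxylic acid, a primary amine on a longer chain or a butyl group on this same carbon would give a number beyond the scatter, since the three groups compared so far are all small. Each of these compounds also keeps the nitro group and the methoxy group, so what happens in this test when either of those is replaced remains an open question.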